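The source may report more compounds than this note shows. Statements on the series, on what has been measured and on what is new or still open speak of the compounds shown alone.

Working notes on the series. Compound 3 `N#CC1=C(N)Oc2c(c3nc4ccccc4nc3c3ccccc23)C12C(=O)N(Cc1cnnn1-c1cccc(Br)c1)c1ccccc12` carries a 3-bromophenyl on an aromatic nitrogen of the shared core. In an ADME assay on L02 cells (Homo sapiens) for antiproliferative activity, read by MTT assay, with a stated time of 48 h (on this read-out higher numbers stand for weaker inhibition and lower numbers for stronger inhibition), compound 3 gives > 50000 nM, which is a limit of the assay and not a number. Its two measured relatives are compound 1 `Cc1cccc(-n2nncc2CN2C(=O)C3(C(C#N)=C(N)Oc4c3c3nc5ccccc5nc3c3ccccc43)c3ccccc32)c1` and compound 2 `N#CC1=C(N)Oc2c(c3nc4ccccc4nc3c3ccccc23)C12C(=O)N(Cc1cnnn1-c1ccc(F)cc1)c1ccccc12`. In this assay compound 1 gives > 50000 nM, again a limit rather than a number. In this assay compound 2 gives > 50000 nM, likewise a limit. Accordingly the three measured steps, a step that the two limits leave unreadable from compound 1 to compound 2, a step that the two limits leave unreadable from compound 1 to compound 3 and a step that the two limits leave unreadable from compound 2 to compound 3, carry no readable size and no direction; they remain unreadable because of the limit of > 50000 nM in this assay, at which 3 of the 3 values shown sit.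

Going by the values given here, compound 4 `Cc1ccc(C)c(-n2nncc2CN2C(=O)C3(C(C#N)=C(N)Oc4c3c3nc5ccccc5nc3c3ccccc43)c3ccccc32)c1` has not been measured in this assay. 2,5-dimethylphenyl in place of 3-bromophenyl on an aromatic nitrogen The steps that bear on this change are the three above, and each is unreadable, so no size and no direction beyond the scatter can be drawn from them. Among the compounds with values here, the plain expectation is that compound 4 behaves like the three measured members and is reported as a limit again. Compound 4 is expected to give 80000 nM, with a range from 40000 nM to 200000 nM. For compound 4 the expected step is a step that the limit leaves unreadable from compound 3 to compound 4, which is not expected to be readable if the assay reports a limit once more.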

Compound 4, half-maximal inhibitory concentration: > 50000 nM
Compound 4 gave a limit, no number; the forecaster's own chance of this, stated with the estimate: 85%; the middle value lies beyond the limit too.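

In this assay compound 4 gives > 50000 nM, which is a limit of the assay and not a number. The steps from compound 1, compound 2 and compound 3 to compound 4 cannot be read, because all four compounds share one reported result: the limit of > 50000 nM in this assay, at which 4 of the 4 values shown sit. The compounds shown leave open whether any of these phenyl groups differ from one another in this assay.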